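A Third Aryl Variation at the Saturated Chain Carbon

This account rests on a few compounds, and the source may have more. Where it says the series, first, only, none or still open, it means among the compounds named here.

Compound 1 `CCOC(=O)c1[nH]c2cc(Cl)ccc2c1/C=N/NC(=O)CCc1ccccc1` was tested in an assay for inhibition of Polyunsaturated fatty acid lipoxygenase ALOX15 (Homo sapiens), with a stated time of 8 min; a lower number here means a stronger inhibitor, a higher number a weaker inhibitor. In this assay compound 1 gives only a limit, > 10000 nM. Compound 2 `CCOC(=O)c1[nH]c2cc(Cl)ccc2c1/C=N/NC(=O)Cc1ccccc1` also reaches only a limit in this assay, > 10000 nM. Compound 3 `CCOC(=O)c1[nH]c2cc(Cl)ccc2c1/C=N/NC(=O)COc1ccc([N+](=O)[O-])cc1` likewise gives only a limit in this assay, > 10000 nM. Accordingly the steps a step that the two limits leave unreadable from compound 1 to compound 2, a step that the two limits leave unreadable from compound 1 to compound 3 and a step that the two limits leave unreadable from compound 2 to compound 3 cannot be sized, a situation summed up by the limit of > 10000 nM in this assay, at which 3 of the 3 values shown sit.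

Compound 4 `CCOC(=O)c1[nH]c2cc(Cl)ccc2c1/C=N/NC(=O)CNc1cccc([N+](=O)[O-])c1` differs from compound 1 by (3-nitrophenyl)amino in place of benzyl on a saturated chain carbon bound to a carbonyl carbon. Among the measured compounds shown here, every measured change at this same saturated chain carbon, whether to phenyl or to 4-nitrophenoxy, has left the value at the limit, so no step in this assay gives a readable direction for the new group. Compound 1 itself stands only at a limit in this assay, > 10000 nM. Compound 4 is therefore expected to remain at or near that limit, with the step that the limit leaves unreadable from compound 1 to compound 4 estimated as not reading beyond the scatter. Compound 4 is estimated at 20000 nM, expected between 5000 nM and 100000 nM.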

Compound 4, half-maximal inhibitory concentration: > 10000 nM
Compound 4: no number, only a limit (the forecaster's own chance of this, stated with the estimate: 85%); the middle value is on the limit's open side.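

In this assay compound 4 gives > 10000 nM as a limit. Among the compounds shown here, no step linking compound 4 to compound 1, compound 2 or compound 3 can be read, and all four stand at one limit: the limit of > 10000 nM in this assay, at which 4 of the 4 values shown sit. The compounds shown leave open whether any group at this saturated chain carbon gives a measurable value.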